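Removing a chloro from an aryl urea: compound 3 to compound 4

The source may hold more compounds than are shown below. What is called first, only, known or untested is meant among the compounds shown, and "the series" means these compounds.

The compounds share one core, a diaryl urea attached through an ether to a pyridine that carries a triazole. Compound 1 `Cn1cnnc1-c1cc(Oc2ccc(NC(=O)Nc3cccc(C(F)(F)F)c3)cc2F)ccn1` gives 6470 nM in a functional assay on MDA-MB-231 cells (Homo sapiens) for antiproliferative activity, read by MTT assay, with a stated time of 72 h; a lower number here means a stronger inhibitor, a higher number a weaker inhibitor. Compound 2 `CN(C)CCn1cnnc1-c1cc(Oc2ccc(NC(=O)Nc3cccc(C(F)(F)F)c3)cc2F)ccn1` gives 16400 nM, and the step of a 2.5-fold higher number from compound 1 to compound 2 (0.40 log units; beyond the scatter) shows that a dimethylaminoethyl chain on the triazole nitrogen is not helpful here. Compound 3 `CCN(CC)CCn1cnnc1-c1cc(Oc2ccc(NC(=O)Nc3ccc(Cl)c(C(F)(F)F)c3)cc2F)ccn1`, which carries a diethylaminoethyl chain and an extra chloro, gives 1540 nM, the lowest of the three numbers; compound 1 lies a good way above it and compound 2 further still.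

Compound 4 `CCN(CC)CCn1cnnc1-c1cc(Oc2ccc(NC(=O)Nc3cccc(C(F)(F)F)c3)cc2F)ccn1` differs from compound 3 only by hydrogen in place of chloro on an aromatic carbon: the chloro ortho to the trifluoromethyl group and para to a large group is replaced by hydrogen. Going by the values given here, no measured pair differs in only this place, so the one measured step, about the chain, does not bear directly on it; compounds 1 and 3 differ in two places at once, and their values show only that the two changes together gave the lower number. A modest step upward in this assay is expected, a 2.6-fold higher number from compound 3 to compound 4 (0.41 log units; beyond the scatter), giving compound 4 an estimated 4000 nM with a range from 1500 nM to 12000 nM.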

Compound 4, half-maximal inhibitory concentration: 720 nM
Estimate against measurement, compound 4: 5.6-fold (0.74 log units) above; measured number outside the range, below it.
By their numbers in this assay, from the lowest: compound 4; then compound 3; then compound 1; then compound 2.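

In this assay, the chloro on the 4-chloro-3-(trifluoromethyl)phenyl group proves dispensable: hydrogen in its place gives a 2.1-fold lower number from compound 3 to compound 4 (0.33 log units; beyond the scatter) and so does better, at least with the diethylaminoethyl chain present. The amine on the chain also matters more than compound 2 alone suggested, since diethylamino in place of dimethylamino gives a 23-fold lower number from compound 2 to compound 4 (1.36 log units; beyond the scatter) in a large step. The chain itself can now help, with a 9.0-fold lower number from compound 1 to compound 4 (0.95 log units; beyond the scatter) set against a 2.5-fold higher number from compound 1 to compound 2 (0.40 log units; beyond the scatter) for the dimethylamino version, so its effect reverses with the amine it carries.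

No measurement at hand accounts for these steps. Going by these compounds, it remains open whether fluoro or methoxy at the chloro's place would match hydrogen, and whether a piperidine, a morpholine or a longer chain would improve on diethylaminoethyl.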